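The source may report more compounds than this note shows. Statements on the series, on what has been measured and on what is new or still open speak of the compounds shown alone.

Compound 1 `COc1ccc(Oc2ccc([N+](=O)[O-])cc2-c2ccsc2S(=O)(=O)N2CCN(C(=O)Nc3ccc([N+](=O)[O-])cc3)CC2)cc1OC` gives > 20000 nM in an ADME assay on HEK-293T cells (Homo sapiens) for cytotoxicity, read by CCK-8 assay, with a stated time of 48 h (on this read-out lower numbers stand for stronger inhibition and higher numbers for weaker inhibition), a limit of the assay and not a number.
Compound 2 `COc1ccc(NC(=O)NCCNS(=O)(=O)c2ccc(-c3ccccc3Oc3ccc([N+](=O)[O-])cc3)s2)cc1` gives > 20000 nM in this assay, again only a limit.
Compound 3 `COc1ccc(NC(=S)NCCNS(=O)(=O)c2sccc2-c2ccc(C)cc2Oc2ccc(O)c(O)c2)cc1` gives > 20000 nM in this assay, once more a limit.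

Compound 3 therefore stands nowhere in particular on the numbers shown: its result is only a limit, and the two other values are limits as well. Within the data shown here, all three readings rest at the same point, (the limit of > 20000 nM in this assay, at which 3 of the 3 values shown sit), so no ordering among compound 1, compound 2 and compound 3 can be drawn, and no step between two measured compounds exists to lean on.

Compound 4 `Cc1ccc(-c2ccsc2S(=O)(=O)NCCNC(=O)Nc2cccc([N+](=O)[O-])c2)c(Oc2ccc(O)c(O)c2)c1` is not yet measured. It differs from compound 3 in one place: a group of 12 heavy atoms (7 carbon, 2 nitrogen, 3 oxygen; one six-membered aromatic ring of carbon only) in place of a group of 11 heavy atoms (8 carbon, 1 nitrogen, 1 oxygen, 1 sulfur; one six-membered aromatic ring of carbon only), on an amine nitrogen. The rest of the molecule is kept.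

Among the measured compounds shown here, with every measured value sitting at the limit, there is no measured step that would point in either direction for this change. The step that the limit leaves unreadable from compound 3 to compound 4 is expected to be none beyond the scatter. Compound 4 is accordingly expected to come out at 30000 nM, with a range from 12000 nM to 100000 nM, most likely reported again only as a limit.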

Compound 4, half-maximal inhibitory concentration: 6800 nM
Compound 4: middle estimate off by 4.4-fold (0.64 log units), on the high side, and the stated range ends above it.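

On the amine nitrogen whose other neighbours are saturated chain carbon, placing (3-nitrophenyl)carbamoyl where compound 3 carries its group of 11 heavy atoms gives, in this assay, an at least 2.9-fold lower number from compound 3 to compound 4 (0.46 log units; beyond the scatter), which shows that a change at this one place can move the read-out beyond the scatter towards stronger inhibition. Compound 3 gives > 20000 nM, a limit of the assay and not a number, so the printed size of the step is only a floor and the true gap may be wider. Compound 4, at 6800 nM, is the only compound shown with a measured number, and it is therefore the first reading in this set that gives this position a value to compare against. The other readings all stay at one point: the limit of > 20000 nM in this assay, at which 3 of the 4 values shown sit.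

The leaving group holds a sulfur atom and the entering group holds more oxygen and nitrogen, so the compounds shown cannot separate what the carbonyl contributes from what the nitro group contributes to the step. They also leave open how the read-out would run with a nitrile or an amine in place of that nitro group, or with a longer chain on the same amine nitrogen.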